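Anilide in place of the acid on the shared core

This account rests on a few compounds, and the source may have more. Where it says the series, first, only, none or still open, it means among the compounds named here.

Compound 1 `C=CC1=C(C(=O)O)C(c2ccc(F)cc2)OC1` is the acid of the shared core with a fluoro on an aromatic carbon. In a functional assay on HeLa cells (Homo sapiens) for cytotoxicity, read by MTT assay, with a stated time of 24 h (on this read-out higher numbers stand for weaker inhibition and lower numbers for stronger inhibition), compound 1 gives 67400 nM, the highest of the two numbers in the set. Compound 2 `C=CC1=C(C(=O)O)C(c2ccc(OC)cc2)OC1` carries a methoxy in place of the fluoro and in this assay compound 2 gives 44300 nM; the step of a 1.5-fold lower number from compound 1 to compound 2 (0.18 log units; within the scatter) stays within the scatter. Compound 3 `C=CC1=C(C(=O)NCCC)C(c2ccc(OC)c(OC)c2)OC1` is an amide, and in this assay compound 3 reaches only a limit of the assay, > 100000 nM. For the measured compounds named here, that limit of > 100000 nM in this assay, at which 1 of the 3 values shown sits, is the sole evidence on an amide here, and compound 3 differs from compound 2 in two places, so no single step to it can be read.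

Compound 4 `C=CC1=C(C(=O)Nc2cccc(C)c2)C(c2ccc(F)cc2)OC1` is not yet measured. It keeps the fluoro of compound 1 and differs from it by (3-methylphenyl)amino in place of hydroxy on a carbonyl carbon. Going by the values given here, the one measured step, a 1.5-fold lower number from compound 1 to compound 2 (0.18 log units; within the scatter), concerns the aromatic substituent and does not touch the carbonyl carbon, so it bears little on this change. The only amide in the set, compound 3, returned no number. The step of a 1.5-fold higher number from compound 1 to compound 4 (0.17 log units; within the scatter) is therefore expected to run toward a higher number, possibly beyond the scatter. Compound 4 is estimated at 100000 nM, ranging from 40000 nM to 250000 nM, with a fair chance that only a limit is returned.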

Compound 4, half-maximal inhibitory concentration: "not active" (no number reported)
Compound 4: no number reported; no gap can be computed for the estimate.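

In this assay, for the compounds shown here, compound 4 is reported as "not active" without a number, so no step from compound 1 to compound 4 can be read. The compounds shown leave open how far, in numerical terms, (3-methylphenyl)amino in place of hydroxy on a carbonyl carbon shifts the read-out of compound 1.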